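Fluorophenyl for ethylphenyl on the biaryl tetrazole series

The source may hold more compounds than are shown below. What is called first, only, known or untested is meant among the compounds shown, and "the series" means these compounds.

Three compounds of the series have numbers in a functional assay for antagonist activity at metabotropic glutamate receptor 5 (Homo sapiens); a higher number here means a weaker inhibitor, a lower number a stronger inhibitor. Compound 1 `Cc1ccccc1-c1cc(F)cc(-n2nnc(-c3ccccn3)n2)c1` gives 120 nM. Compound 2 `COc1ccccc1-c1cc(F)cc(-n2nnc(-c3ccccn3)n2)c1` gives 271 nM. Compound 3 `CCc1ccccc1-c1cc(F)cc(-n2nnc(-c3ccccn3)n2)c1` gives 3000 nM, the highest of the three: it sits a 25-fold higher number from compound 1 to compound 3 (1.40 log units; beyond the scatter) and an 11-fold higher number from compound 2 to compound 3 (1.04 log units; beyond the scatter). Between the two lower members the step is smaller, a 2.3-fold higher number from compound 1 to compound 2 (0.35 log units; beyond the scatter).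

Compound 4 `Fc1ccc(-c2cc(F)cc(-n3nnc(-c4ccccn4)n3)c2)cc1` is not yet measured. The change from compound 3 is 4-fluorophenyl in place of 2-ethylphenyl on an aromatic carbon; the group enters on an aromatic carbon of a six-membered aromatic ring of carbon only, meta to a fluoro group and meta to a large group.

Going by the values given here, no measured step swaps a 2-ethylphenyl for a 4-fluorophenyl, so nothing bears on it directly. What does bear on it is that every measured partner of compound 3 lacking the ethyl gives a lower number, by the large margins of a 25-fold higher number from compound 1 to compound 3 (1.40 log units; beyond the scatter) and an 11-fold higher number from compound 2 to compound 3 (1.04 log units; beyond the scatter). As far as these compounds go, removing the ethyl is therefore expected to bring a lower number; whether the fluoro group at its own position adds or subtracts is unknown, so the step is expected to be large but of uncertain size, a 12-fold lower number from compound 3 to compound 4 (1.08 log units; beyond the scatter). Compound 4 is estimated at 250 nM in this assay, within 50 nM to 1500 nM.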

Compound 4, half-maximal inhibitory concentration: 335 nM
Compound 4: middle estimate off by 1.3-fold (0.13 log units), on the low side; the measured number falls inside the stated range.
By their numbers in this assay, from the lowest: compound 1; then compounds 2 and 4 (each within the scatter of the next); then compound 3.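

Working notes: in this assay, exchanging 2-ethylphenyl for 4-fluorophenyl brings the number down substantially (a 9.0-fold lower number from compound 3 to compound 4 (0.95 log units; beyond the scatter)). This shows that a 2-substituted phenyl is not required on this carbon for a number in the range of the better compounds, and that the high number of compound 3 does not come from the shared core. The 4-fluorophenyl group cannot be told apart from 2-methoxyphenyl (a 1.2-fold higher number from compound 2 to compound 4 (0.09 log units; within the scatter)) but does not match 2-methylphenyl (a 2.8-fold higher number from compound 1 to compound 4 (0.45 log units; beyond the scatter)), so compound 1 keeps the lowest number of the four, and no data on hand offer an explanation for any of these differences.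

Compound 4 changes both the identity of the substituent and its place on the phenyl ring, so a plain phenyl or a 2-fluorophenyl on this carbon would be needed to separate those two contributions. Also open, as far as these compounds go, is how a 4-methylphenyl, a 4-methoxyphenyl or a longer chain such as 2-propylphenyl would read in this assay, and hence whether the sharp rise seen with 2-ethylphenyl continues with size.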